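Pendant aryl substituent changes on the shared core

The compounds below may be only part of what the source reports. "The series", "measured", "known", "first", "only" and "open" are said of these compounds alone.

Measured compounds:
compound 1, `CCCS(=O)(=O)Nc1ccc(F)c(C(=O)c2n[nH]c3ncc(-c4ccc(C)c(C)c4)cc23)c1F`, giving 20% in an assay for binding affinity to dual specificity mitogen-activated protein kinase kinase 4 (Homo sapiens), read by KINOMEscan, tested at 100 nM; a higher number here means a weaker effect of the compound at the concentration tested, a lower number a stronger effect
compound 2, `CCCS(=O)(=O)Nc1ccc(F)c(C(=O)c2n[nH]c3ncc(-c4ccc(S(=O)(=O)NCC)cc4)cc23)c1F`, giving 3% in this assay

Within the data shown here, compound 2 stands lowest of the two numbers in this assay; its nearest neighbour is compound 1, and the single measured step, a number 17 percentage points lower from compound 1 to compound 2 (beyond the scatter), lies beyond the scatter.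

The next compound, compound 3, `CCCS(=O)(=O)Nc1ccc(F)c(C(=O)c2n[nH]c3ncc(-c4ccc(C(=O)O)cc4)cc23)c1F`, keeps the whole of compound 2 apart from the group on the pendant aromatic ring: carboxy in place of ethylsulfamoyl on an aromatic carbon.

Among the measured compounds shown here, no measured step covers this change directly. For the measured compounds named here, the one step that exists, a number 17 percentage points lower from compound 1 to compound 2 (beyond the scatter), concerns a different exchange, 4-(ethylsulfamoyl)phenyl in place of 3,4-dimethylphenyl, and shows only that the read-out moves with the group on that ring. Carboxy and ethylsulfamoyl share a hydrogen-bond donor and an acceptor, so a small step, if any, is expected, with a slight lean upward because compound 2 already sits at 3% and has little room to fall.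

The step from compound 2 to compound 3 is therefore estimated at a number 5 percentage points higher from compound 2 to compound 3 (within the scatter). For compound 3 the expected value in this assay is 8%, within 1% to 30%.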

Compound 3, a percentage reported as activity, at one concentration (the size of the read-out at that concentration, not a potency): 0.1%
Beside the measured number, compound 3's estimate is 7.9 percentage points above it; the whole stated range lies above it.
By their numbers in this assay, from the lowest: compounds 3 and 2 (each within the scatter of the next); then compound 1.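

Carboxy and ethylsulfamoyl on this aromatic carbon, para to a large group, cannot be told apart in this assay (a number 2.9 percentage points lower from compound 2 to compound 3 (within the scatter)), so the full ethylsulfamoyl group is not needed for a read-out in this range and a group with fewer heavy atoms serves equally well. The step away from the 3,4-dimethylphenyl ring is now seen for a second group (a number 19.9 percentage points lower from compound 1 to compound 3 (beyond the scatter)), which shows that the separation from compound 1 is not particular to 4-(ethylsulfamoyl)phenyl. No measurement here bears on why these two groups stand apart from 3,4-dimethylphenyl.

The compounds shown leave open whether a primary carboxamide, a methyl ester, an amine or a longer chain on the sulfamoyl nitrogen at the same place would stay within the scatter of compound 2 and compound 3 or fall back toward compound 1. They also leave open whether a full potency measurement, rather than a read-out at one concentration, would separate compound 2 from compound 3.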